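The source may report more compounds than this note shows. Statements on the series, on what has been measured and on what is new or still open speak of the compounds shown alone.

In a functional assay on HCT-116 cells (Homo sapiens) for cytotoxicity, read by MTT assay, with a stated time of 48 h, in the presence of a further agent that is not named here (on this read-out lower numbers stand for an effect already at smaller amounts and higher numbers for an effect only at larger amounts of compound), compound 1 (`Cn1nc(C(F)(F)F)c2c(-c3ccccc3)cc(NNC(=O)Nc3cc(Cl)nc(Cl)c3)nc21`) gives 18100 nM, compound 2 (`CC(C)c1cc(NNC(=O)Nc2cc(Cl)nc(Cl)c2)nc2c1c(C(F)(F)F)nn2C`) gives 27200 nM, and compound 3 (`Cc1nn(C)c2nc(NNC(=O)Nc3cc(Cl)nc(Cl)c3)cc(-c3ccco3)c12`) gives the highest number of the three, 69200 nM, beyond the scatter of both others. In compound 4 (`Cc1nn(C)c2nc(NNC(=O)Nc3cc(Cl)nc(Cl)c3)cc(-c3ccc(Cl)s3)c12`), 5-chlorothiophen-2-yl takes the place of furan-2-yl on an aromatic carbon: 5-chlorothiophen-2-yl in place of furan-2-yl on an aromatic carbon. Among the measured compounds shown here, no measured step involves either group. The only one available, a 1.5-fold higher number from compound 1 to compound 2 (0.18 log units; within the scatter), exchanges phenyl for isopropyl on an aromatic carbon and is small. A modest move toward the lower numbers of the other compounds is therefore expected, though the data do not settle its direction. The estimated step is a 1.7-fold lower number from compound 3 to compound 4 (0.24 log units; within the scatter). Compound 4 is expected at 40000 nM, within an estimated range of 13000 nM to 100000 nM.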

Compound 4, half-maximal effective concentration: 42100 nM
Compound 4: middle estimate off by 1.1-fold (0.02 log units), on the low side; the measured number falls inside the stated range.
By their numbers in this assay, from the lowest: compounds 1, 2, 4 and 3 (each within the scatter of the next, the first and the last beyond it).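

In this assay, 5-chlorothiophen-2-yl in place of furan-2-yl, on the aromatic carbon opposite the ring nitrogen, gives a 1.6-fold lower number from compound 3 to compound 4 (0.22 log units; within the scatter) and so adds a second step at this position that stays within the scatter, alongside a 1.5-fold higher number from compound 1 to compound 2 (0.18 log units; within the scatter). A five-membered aromatic ring with sulfur and chlorine thus serves here much as one with oxygen does. No measurement of any property bears on this step.

From the compounds shown here alone, the share of the sulfur and of the chlorine in this step stays open. So does whether an amine, a carboxylic acid or a longer chain at this position would move the number beyond the scatter.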